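A few compounds are considered here, and "the series" means these few. Any claim that something is new, unique, unknown or untested is made for them only; others in the source may bear on it.

Measured compounds:
compound 1 `O=C(O)Cc1sc(C(c2ccc(F)cc2)c2ccc(F)cc2)nc1-c1ccc(Cl)cc1`: 180 nM
compound 2 `O=C(O)Cc1sc(C(c2ccccc2)c2ccc(Cl)cc2)nc1-c1ccc(F)cc1`: 79 nM

In an in vitro functional assay on HEK285-7 cells for antagonist activity at prostaglandin D2 receptor 2 (Homo sapiens), read by BRET and beta-arrestin recruitment (a lower number here means a stronger inhibitor, a higher number a weaker inhibitor), compound 1 gives 180 nM, the higher of the two numbers, while compound 2 gives 79 nM, a gap beyond the usual scatter. Compound 3 `O=C(O)Cc1sc(C(c2ccc(F)cc2)c2ccc(F)cc2)nc1-c1ccnc(N2CCCC2)c1` has not yet been measured. It differs from compound 1 in one place: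
2-(pyrrolidin-1-yl)pyridin-4-yl in place of 4-chlorophenyl on an aromatic carbon
For the measured compounds named here, no measured pair shows this change, so its effect in this assay is unknown; a modest step in either direction, or none beyond the scatter, is expected. For compound 3 the estimated value is 200 nM, ranging from 40 nM to 1000 nM. This estimate means an expected step of a 1.1-fold higher number from compound 1 to compound 3 (0.05 log units; within the scatter).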

Compound 3, half-maximal inhibitory concentration: > 100000 nM
Compound 3 was reported as a limit; the forecaster's own chance of this, stated with the estimate: 5%; middle value at least 500-fold (2.69 log units) from the limit.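

In this assay compound 3 gives > 100000 nM, a limit of the assay and not a number. Compounds 1 and 2 both carry a halogen-substituted phenyl group on this aromatic carbon next to the ring nitrogen, so they did not show how this position responds to a different ring. Placing 2-(pyrrolidin-1-yl)pyridin-4-yl here in place of 4-chlorophenyl gives an at least 550-fold higher number from compound 1 to compound 3 (2.74 log units; beyond the scatter), which shows that this position does not accept every ring group.

As far as these compounds go, it remains open whether the pyridine ring or the pyrrolidine is responsible. Plain pyridin-4-yl and 4-(pyrrolidin-1-yl)phenyl at this position would separate the two.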